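The source may hold more compounds than are shown below. What is called first, only, known or untested is meant among the compounds shown, and "the series" means these compounds.

Compound 1, `O=S(=O)(Nc1ccccc1NS(=O)(=O)c1ccccc1)c1ccccc1`: 32200 nM
Compound 2, `O=S(=O)(Nc1ccccc1NS(=O)(=O)c1ccc(F)cc1)c1ccc(F)cc1`: 28300 nM
Compound 3, `Cc1ccc(NS(=O)(=O)c2ccccc2)c(NS(=O)(=O)c2ccccc2)c1`: 28800 nM

All three were measured in an assay for binding affinity to protein lin-28 homolog A (Mus musculus), with a stated time of 1 h; a lower number here means a stronger inhibitor, a higher number a weaker inhibitor. Compound 3 differs from compound 1 by methyl in place of hydrogen on an aromatic carbon, and this gives a 1.1-fold lower number from compound 1 to compound 3 (0.05 log units; within the scatter). Compound 2 and compound 1 differ in more than one place, so the difference between the two cores is not broken down here; their values lie within the scatter of each other, as do those of compound 2 and compound 3.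

Compound 4, `Cc1ccc(NS(=O)(=O)c2ccc(F)cc2)c(NS(=O)(=O)c2ccc(F)cc2)c1`, is still to be measured in this assay. It differs from compound 2 by methyl in place of hydrogen on an aromatic carbon, and the place of the change reads the same as for the step from compound 1 to compound 3, so it is the same change. Because that earlier step was a 1.1-fold lower number from compound 1 to compound 3 (0.05 log units; within the scatter), the step from compound 2 to compound 4 is expected to be a 1.0-fold lower number from compound 2 to compound 4 (0.02 log units; within the scatter). Compound 4 is therefore estimated at 27000 nM, between 14000 nM and 55000 nM.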

Compound 4, half-maximal inhibitory concentration: 16200 nM
For compound 4 the middle estimate is 1.7-fold (0.22 log units) above the measured one; measured number inside the range.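

In this assay, methyl in place of hydrogen on the second core gives a 1.7-fold lower number from compound 2 to compound 4 (0.24 log units; within the scatter). Set beside the earlier step, the change reads alike on both cores: the same change on two cores in this assay, a 1.1-fold lower number (0.05 log units; within the scatter) from compound 1 to compound 3 and a 1.7-fold lower number (0.24 log units; within the scatter) from compound 2 to compound 4, 1.6-fold (0.19 log units) apart, within the scatter of two such steps. This shows that on these two cores the methyl moves the number by no more than the scatter, but it does not show that the methyl has a real effect, or that the step would stay this small on any other core.

Going by these compounds, only hydrogen and methyl appear at this place, so what a longer chain, an amine or a carboxylic acid would do there remains open. Also open, on these data alone, is how the methyl step would read on a core carrying chlorine where these compounds carry hydrogen or fluorine.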